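Adding a Methyl to the Difluoromethyl Group

The compounds below may be only part of what the source reports. "The series", "measured", "known", "first", "only" and "open" are said of these compounds alone.

Three measured compounds share one core and differ only in the group on one aromatic carbon. In an assay on cells for inhibition of cytochrome P450 11B2, mitochondrial (Homo sapiens), read by HPLC, with a stated time of 90 min (on this read-out lower numbers stand for stronger inhibition and higher numbers for weaker inhibition), compound 1 `CCc1ncncc1-c1nc2cc(F)c(F)cc2n1C1CC1` gives 8 nM. Compound 2 `CNc1ncncc1-c1nc2cc(F)c(F)cc2n1C1CC1` in this assay sits at < 2 nM, which is a limit of the assay rather than a number. Compound 3 `Fc1cc2nc(-c3cncnc3C(F)F)n(C3CC3)c2cc1F` gives 18 nM in this assay, the highest of the two plain numbers shown, and the step of a 2.3-fold higher number from compound 1 to compound 3 (0.35 log units; beyond the scatter) places it above compound 1. Compound 4 `CC(F)(F)c1ncncc1-c1nc2cc(F)c(F)cc2n1C1CC1` is not yet measured; it differs from compound 3 by methyl in place of hydrogen on a saturated chain carbon bound to an aromatic carbon and two fluorine atoms, so difluoromethyl becomes 1,1-difluoroethyl. For the measured compounds named here, no measured step changes this chain length directly; the nearest comparison, a 2.3-fold higher number from compound 1 to compound 3 (0.35 log units; beyond the scatter), was modest, so little movement is expected. Compound 4 is estimated at 13 nM, between 5 nM and 35 nM, an expected step of a 1.4-fold lower number from compound 3 to compound 4 (0.14 log units; within the scatter) within the scatter.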

Compound 4, half-maximal inhibitory concentration: 50 nM
Compound 4: the middle estimate sits 3.8-fold (0.59 log units) below what was measured; measured number above the stated range.
By their numbers in this assay, from the lowest: compound 1; then compound 3; then compound 4. At a limit, below all of these: compound 2.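

In this assay, a single added methyl on this saturated chain carbon moves the number beyond the scatter, giving a 2.8-fold higher number from compound 3 to compound 4 (0.44 log units; beyond the scatter). Two wider comparisons, a 6.3-fold higher number from compound 1 to compound 4 (0.80 log units; beyond the scatter) and an at least 25-fold higher number from compound 2 to compound 4 (1.39 log units; beyond the scatter), put the 1,1-difluoroethyl group behind both the ethyl and the methylamino groups on this aromatic carbon. Compound 2 carries a limit, not a number, so its step is a bound: the limit of < 2 nM in this assay, at which 1 of the 4 values shown sits.

The compounds shown leave open whether trifluoromethyl would follow the same trend among the fluorinated groups. They also leave open whether an ethylamino or a dimethylamino group would stay close to compound 2.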